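Biaryl aniline series: benzimidazolyl to methylpyrazolyl

This account rests on a few compounds, and the source may have more. Where it says the series, first, only, none or still open, it means among the compounds named here.

Compound 1, `CCN(c1ccc(C#N)c(Cl)c1)c1cc(-c2cccs2)ccc1C`: "not determined" (no result reported)
Compound 2, `CCN(c1ccc(C#N)c(Cl)c1)c1cc(-c2ccc(F)nc2)ccc1C`: > 30000 nM
Compound 3, `CCN(c1ccc(C#N)c(Cl)c1)c1cc(-n2cnc3ccccc32)ccc1C`: 8560 nM

Going by the values given here, in a functional assay on VCaP cells (Homo sapiens) for antiproliferative activity, read by CCK-8 assay, with a stated time of 6 days (on this read-out lower numbers stand for stronger inhibition and higher numbers for weaker inhibition), compound 3 gives 8560 nM, the only single number in the set. For compound 2 the result is a limit of the assay, > 30000 nM. Compound 1 has no result. Among the compounds with values here, the one measured step, an at least 3.5-fold lower number from compound 2 to compound 3 (0.54 log units; beyond the scatter), showed the benzimidazolyl gaining over a smaller aromatic group at the same carbon. Compound 4, `CCN(c1ccc(C#N)c(Cl)c1)c1cc(-c2ccnn2C)ccc1C`, differs from compound 3 by 1-methyl-1H-pyrazol-5-yl in place of 1H-benzimidazol-1-yl on an aromatic carbon; the six-membered aromatic ring of carbon only is lost and a single five-membered ring remains. The measured step points the other way, so a weaker result in this assay is expected. Compound 4 is estimated at 20000 nM, range 6000 nM to 60000 nM, an expected step of a 2.3-fold higher number from compound 3 to compound 4 (0.37 log units; beyond the scatter). A limit is plausible, as the limit of > 30000 nM in this assay, at which 1 of the 3 values shown sits, shows.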

Compound 4, half-maximal inhibitory concentration: 1670 nM
Compound 4: the middle estimate sits 12-fold (1.08 log units) above what was measured, and the stated range ends above it.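

In this assay, a smaller group at this carbon, para to the methyl group, is better than the larger bicyclic one: a 5.1-fold lower number from compound 3 to compound 4 (0.71 log units; beyond the scatter). The six-membered aromatic ring of carbon only in the 1H-benzimidazol-1-yl is therefore not required for activity in these compounds, and the 1-methyl-1H-pyrazol-5-yl also improves on the 6-fluoropyridin-3-yl, with an at least 17-fold lower number from compound 2 to compound 4 (1.25 log units; beyond the scatter). That step has only a bound, since compound 2 stands at a limit of the assay: the limit of > 30000 nM in this assay, at which 1 of the 4 values shown sits.

On these data alone, whether the methyl group of the 1-methyl-1H-pyrazol-5-yl is needed stays open. So does how an amine or a carboxylic acid in its place would read.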